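The source may hold more compounds than are shown below. What is called first, only, known or untested is meant among the compounds shown, and "the series" means these compounds.

Three compounds share one core and differ only in the group on an amine nitrogen whose other neighbour is a double-bonded ring carbon. Compound 1 `Cc1ccc(NC2=CC(=O)c3c(nc4n3[C@H]3OC[C@@H](O)[C@H]3OC4)C2=O)cc1C` carries a 3,4-dimethylphenyl there, and in a functional assay on HeLa cells (Homo sapiens) for inhibition, read by sulforhodamine B assay (on this read-out higher numbers stand for weaker inhibition and lower numbers for stronger inhibition), compound 1 gives 4320 nM, the lower of the two numbers recorded. Compound 2 `O=C1C=C(Nc2ccccc2)C(=O)c2c1nc1n2[C@H]2OC[C@@H](O)[C@H]2OC1` carries a plain phenyl; in this assay compound 2 gives 5620 nM, which sits within the scatter of compound 1, so the two cannot be ordered. Compound 3 `O=C1C=C(NC2CCCCC2)C(=O)c2c1nc1n2[C@H]2OC[C@@H](O)[C@H]2OC1` carries a cyclohexyl, and in this assay compound 3 reaches only a limit of > 16000 nM. Going by the values given here, the single countable step, an at least 2.8-fold higher number from compound 2 to compound 3 (0.45 log units; beyond the scatter), shows that a saturated ring in place of the aromatic one weakens inhibition, though its full size is unknown because that end rests on (the limit of > 16000 nM in this assay, at which 1 of the 3 values shown sits). Compound 4 `O=C1C(NCc2ccccc2)=CC(=O)c2c1nc1n2[C@H]2OC[C@@H](O)[C@H]2OC1` is the benzyl analogue: benzyl in place of 3,4-dimethylphenyl on an amine nitrogen. The aromatic ring stays, while the two methyls are gone. Among the compounds with values here, no measured step covers exactly this change; the cyclohexyl step is the only guide and points toward weaker inhibition. A modest rise is therefore expected, a 2.1-fold higher number from compound 1 to compound 4 (0.32 log units; beyond the scatter). Compound 4 is estimated at 9000 nM, between 3500 nM and 25000 nM.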

Compound 4, half-maximal inhibitory concentration: 11000 nM
Compound 4: middle estimate off by 1.2-fold (0.09 log units), on the low side; the range from low to high includes it.
By their numbers in this assay, from the lowest: compounds 1, 2 and 4 (each within the scatter of the next, the first and the last beyond it). At a limit, above all of these: compound 3.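

With a 2.5-fold higher number from compound 1 to compound 4 (0.41 log units; beyond the scatter), the result shows that keeping an aromatic ring on the amine nitrogen does not by itself preserve the inhibition seen with compound 1 in this assay: the benzyl group still gives weaker inhibition than 3,4-dimethylphenyl. The change is visible only against compound 1, since compound 2 and compound 4 lie within the scatter of each other and cannot be ordered. How compound 4 stands against the cyclohexyl of compound 3 cannot be read, because that comparison rests on a limit: the limit of > 16000 nM in this assay, at which 1 of the 4 values shown sits.

The compounds shown do not separate the loss of the two methyls from the insertion of the methylene link. A 3,4-dimethylbenzyl group or a longer chain such as phenethyl on this nitrogen remains an open case.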